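The compounds below may be only part of what the source reports. "The series", "measured", "known", "first", "only" and "open" are said of these compounds alone.

Compound 1 `Cc1ccc(N2CCN(C(=S)N/N=C3\C(=O)Nc4ccc(Cl)cc43)CC2)c(C)c1` gives 10800 nM in a functional assay on MCF7 cells (Homo sapiens) for inhibition, read by MTT assay, with a stated time of 72 h; on this read-out higher numbers stand for weaker inhibition and lower numbers for stronger inhibition.
Compound 2 `O=C1Nc2ccc(Cl)cc2/C1=N/NC(=S)N1CCN(c2ccccc2Cl)CC1` gives 11700 nM in this assay.
Compound 3 `O=C1Nc2ccc(Cl)cc2/C1=N/NC(=S)N1CCN(c2ccc(F)cc2)CC1` gives 12300 nM in this assay.

Compound 3 does not stand apart from the others: the steps of a 1.1-fold higher number from compound 1 to compound 3 (0.06 log units; within the scatter) and a 1.1-fold higher number from compound 2 to compound 3 (0.02 log units; within the scatter) both stay within the scatter, as does a 1.1-fold higher number from compound 1 to compound 2 (0.03 log units; within the scatter). Compound 4 `O=C1Nc2ccc(Cl)cc2/C1=N/NC(=S)N1CCN(c2ccc([N+](=O)[O-])cc2)CC1` differs from compound 3 by nitro in place of fluoro on an aromatic carbon. The three measured steps all exchange one group on the amine nitrogen in the ring without moving the number, and nothing in the data separates the nitro case from them. For compound 4 no step beyond the scatter is therefore expected, as given by a 1.0-fold lower number from compound 3 to compound 4 (0.01 log units; within the scatter). Compound 4 is estimated at 12000 nM, with a range from 5000 nM to 30000 nM.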

Compound 4, half-maximal inhibitory concentration: 20900 nM
Compound 4: the middle estimate sits 1.7-fold (0.24 log units) below what was measured; the measured number falls inside the stated range.
By their numbers in this assay, from the lowest: compounds 1, 2, 3 and 4 (each within the scatter of the next).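

With nitro on the aromatic carbon, the number in this assay still does not separate from the others: the data show a 1.7-fold higher number from compound 3 to compound 4 (0.23 log units; within the scatter), a 1.8-fold higher number from compound 2 to compound 4 (0.25 log units; within the scatter) and a 1.9-fold higher number from compound 1 to compound 4 (0.29 log units; within the scatter). The 4-nitrophenyl group therefore joins the other three aryl groups on the amine nitrogen in the ring, extending this flat picture to a group with hydrogen-bond acceptors. Nothing available bears on why these numbers stay together. Still open, as far as these compounds go, is whether an amine or a carboxylic acid at this aromatic carbon, or a longer chain in place of the aryl group, would give a step beyond the scatter.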